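From a Small Amine to a Two-Ring Amine

The source may report more compounds than this note shows. Statements on the series, on what has been measured and on what is new or still open speak of the compounds shown alone.

Measured so far:
Compound 1, `CN(C)c1ccc2cc(NC(=O)CCc3ccc(C(F)(F)F)cc3)ccc2n1`, gives 13 nM in an assay on isolated protein for displacement of a labelled ligand from melanin-concentrating hormone receptor 1 (Homo sapiens); on this read-out higher numbers stand for weaker inhibition and lower numbers for stronger inhibition.
Compound 2, `CC(C)N(C)c1ccc2cc(NC(=O)CCc3ccc(C(F)(F)F)cc3)ccc2n1`, gives 2 nM in this assay.
Compound 3, `CN(c1ccc2cc(NC(=O)CCc3ccc(C(F)(F)F)cc3)ccc2n1)C1CCCC1`, gives 2 nM in this assay.

Compound 2 stands level with compound 3 at the digits printed, and together they hold the lowest numbers of the three. Compound 1 is the farthest from compound 2: the step is a 6.5-fold lower number from compound 1 to compound 2 (0.81 log units; beyond the scatter).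

Compound 4, `O=C(CCc1ccc(C(F)(F)F)cc1)Nc1ccc2nc(N3CCC4(CCNC4)C3)ccc2c1`, differs from compound 2 in one place: a group of 9 heavy atoms (7 carbon, 2 nitrogen; 2 five-membered non-aromatic rings with 1 hetero atom each) in place of a group of 5 heavy atoms (4 carbon, 1 nitrogen; no ring), on an aromatic carbon.

Among the measured compounds shown here, two measured steps touch the same place. a 6.5-fold lower number from compound 1 to compound 2 (0.81 log units; beyond the scatter) and a 6.5-fold lower number from compound 1 to compound 3 (0.81 log units; beyond the scatter) both put a larger group in place of methyl on the nitrogen, and both lowered the number by the same modest amount. no change at the digits printed from compound 2 to compound 3 (within the scatter) shows that going on from isopropyl to cyclopentyl brought no further change. So at this place a larger group has so far been at least as good as a small one, but no measured compound carries a group with rings and a hydrogen-bond donor here, so the direction of this step is open. I expect no more than a modest change, most likely a slightly higher number: a 2.0-fold higher number from compound 2 to compound 4 (0.30 log units; within the scatter).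

Compound 4 is therefore estimated at 4 nM, with a range from 0.7 nM to 25 nM.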

Compound 4, half-maximal inhibitory concentration: 0.5 nM
For compound 4 the middle estimate is 8.0-fold (0.90 log units) above the measured one; measured number below the stated range.
By their numbers in this assay, from the lowest: compound 4; then compounds 2 and 3 (each within the scatter of the next); then compound 1.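

Compounds 2 and 3 had suggested that enlarging the group on this aromatic carbon, next to the ring nitrogen, had stopped paying off, yet compound 4 shows that there was still room for improvement in this assay. Its group with two five-membered rings gives a further gain over both the open-chain isopropyl(methyl)amino group (a 4.0-fold lower number from compound 2 to compound 4 (0.60 log units; beyond the scatter)) and the cyclopentyl-bearing amine (a 4.0-fold lower number from compound 3 to compound 4 (0.60 log units; beyond the scatter)), which makes compound 4 the most potent of the four, and the overall change from the smallest amine is large (a 26-fold lower number from compound 1 to compound 4 (1.41 log units; beyond the scatter)). Nothing available here bears on why the new group gives this lower number.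

The entering group differs from the earlier ones in size, in its rings and in carrying a hydrogen-bond donor, and these compounds cannot separate those features. A version with a methyl group on the ring amine nitrogen, or a single pyrrolidine or piperidine ring at this place, would be needed to show which feature goes with the gain.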